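This account rests on a few compounds, and the source may have more. Where it says the series, first, only, none or still open, it means among the compounds named here.

Within the data shown here, compound 2, whose structure is `C/C=C(\C)C(=O)C[C@H]1C2=COC(/C=C/[C@H](C)[C@@H](C)O)=CC2=C(Cl)C(=O)[C@@]1(C)O`, is one of two compounds measured in a functional assay on KB cells (Homo sapiens) for cytotoxicity, read by MTT assay, with a stated time of 72 h; a lower number here means a stronger inhibitor, a higher number a weaker inhibitor. In that test compound 2 gives 0.0012 nM, the lowest number of the pair. The other is compound 1, with the structure `C/C=C(\Cl)C(=O)[C@@](C)(O)[C@H]1CC(=O)C(C)=C2C=C(/C=C/[C@@H](C)[C@@H](C)O)OC=C21`; in this assay compound 1 gives 0.0018 nM, and the gap between the two falls within the usual scatter, so the two cannot be told apart on these numbers. Among the measured compounds shown here, compound 1 and compound 2 differ in more than one place, so no single step between them is counted.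

Compound 3, with the structure `C/C=C(\C)C(=O)C[C@H]1C2=COC(/C=C/[C@@H](C)[C@@H](C)O)=CC2=C(Cl)C(=O)[C@@]1(C)O`, is not yet measured. It relates to compound 2 by the two compounds have the same atoms and bonds and differ only in configuration as drawn: 1 of 6 stereo elements differ; a stereocentre at a saturated chain carbon is drawn S in compound 2 and R in compound 3. For the measured compounds named here, no step between two measured compounds resembles this change, so the expected size rests on the change alone. For compound 3 a step of a 2.5-fold higher number from compound 2 to compound 3 (0.40 log units; beyond the scatter) in this assay is expected, toward a slightly weaker compound, though the direction is uncertain. Compound 3 is therefore estimated at 0.003 nM, with a range from 0.0006 nM to 0.02 nM.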

Compound 3, half-maximal inhibitory concentration: 0.0023 nM
Estimate against measurement, compound 3: 1.3-fold (0.12 log units) above, and the stated range covers the measured number.
By their numbers in this assay, from the lowest: compounds 2, 1 and 3 (each within the scatter of the next).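

In this assay, among these compounds, the one pair that differs in a single place shows a 1.9-fold higher number from compound 2 to compound 3 (0.28 log units; within the scatter). Reversing this stereocentre at a saturated chain carbon from S to R therefore gives two compounds that cannot be told apart on these numbers, so this test detects no need for one particular configuration at this carbon. The comparison points to this one carbon because nothing else separates the pair: the fact that compounds 2 and 3 differ only in the configuration as drawn.

From the compounds shown here alone, only the configuration changes here, so it remains open whether a different group at this carbon, such as an amine or a longer chain, would also keep the number within the scatter. Going by these compounds, it also remains open whether reversing any of the other stereo elements would give a similarly small step.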